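The source may hold more compounds than are shown below. What is called first, only, known or untested is meant among the compounds shown, and "the series" means these compounds.

Working notes on the series. Compound 1, `CSc1cnc2ccccc2c1[Se]CC#CCOC(=O)c1ccc(C(=O)O)cc1`, gives 19.1 ug/mL in a functional assay on P388 cells (Mus musculus) for antiproliferative activity, with a stated time of 72 h; on this read-out lower numbers stand for stronger inhibition and higher numbers for weaker inhibition. Compound 2, `ClCC#CCSc1cnc2ccccc2c1Cl`, gives 13.4 ug/mL in this assay. Compound 1 carries the highest of the two numbers, but its value and that of compound 2 lie within the scatter of each other, so nothing separates the two on this read-out. Among the compounds with values here, no pair of measured compounds differing in a single place is available, and compound 2 differs from compound 1 in more than one region, so no measured step informs the change considered here.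

Compound 3, `CSc1cnc2ccccc2c1[Se]CC#CCOC(=O)/C=C/c1ccccc1`, has not yet been measured. It differs from compound 1 as 2-phenylethenyl in place of 4-carboxyphenyl on a carbonyl carbon. The group that leaves brings one hydrogen-bond donor and one hydrogen-bond acceptor; the group that enters brings none, and both keep one six-membered aromatic ring of carbon only and one double bond outside aromatic rings.

Within the data shown here, with no measured step of this kind, the step of a 1.3-fold lower number from compound 1 to compound 3 (0.10 log units; within the scatter) is expected to fall within the scatter, in no clear direction. Compound 3 is therefore expected to give 15 ug/mL in this assay, with a range from 6 ug/mL to 40 ug/mL.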

Compound 3, concentration for 50% inhibition: 43.9 ug/mL
Estimate against measurement, compound 3: 2.9-fold (0.47 log units) below; the measured number lies above the stated range.
By their numbers in this assay, from the lowest: compounds 2 and 1 (each within the scatter of the next); then compound 3.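

Within the series, this is the first change in a single place that can be read: in this assay, 2-phenylethenyl in place of 4-carboxyphenyl on a carbonyl carbon gives a 2.3-fold higher number from compound 1 to compound 3 (0.36 log units; beyond the scatter), a modest step, which shows that the group held at this position does bear on the read-out. Higher numbers here stand for weaker inhibition, so the group with a hydrogen-bond donor and a hydrogen-bond acceptor goes with the stronger inhibition of this pair, while both groups keep one six-membered aromatic ring of carbon only and one double bond outside aromatic rings. Nothing at hand accounts for the step.

The compounds shown leave open whether the step follows the loss of the carboxylic acid or the change in how the aromatic ring is joined to the carbonyl carbon, as the two groups differ in both; a plain phenyl group and a 2-(4-carboxyphenyl)ethenyl group at this position would separate these two readings. From the compounds shown here alone, whether a step of this size recurs with other groups on the same carbonyl carbon also remains open.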